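The source may report more compounds than this note shows. Statements on the series, on what has been measured and on what is new or still open speak of the compounds shown alone.

Two compounds of the series have been run in a functional assay on the whole organism (strain Albino Swiss CD1) with Mus musculus as the target, in the maximal electroshock model (on this read-out higher numbers stand for an effect only at larger amounts of compound and lower numbers for an effect already at smaller amounts), so far. Compound 1, `CC(C(=O)NCc1cccc(C(F)(F)F)c1)N1C(=O)CCC1=O`, gives 92.4 mg/kg in this assay. Compound 2, `CC1CC(=O)N(C(C)C(=O)NCc2ccccc2)C1=O`, gives 106 mg/kg in this assay, which is the higher of the two numbers; the gap to compound 1 is within the usual scatter, so the two read as equivalent on this evidence. Compound 3, `CC1CC(=O)N(C(C)C(=O)NCc2cccc(F)c2)C1=O`, is the next member to be tested. It differs from compound 2 by one change only, (fluoro in place of hydrogen on an aromatic carbon), that is fluoro in place of hydrogen on an aromatic carbon of the benzyl group. Among the measured compounds shown here, with only two measured points and no single-change step between them, there is no basis for expecting a move beyond the scatter; the expected step of a 1.2-fold lower number from compound 2 to compound 3 (0.07 log units; within the scatter) is accordingly small. For compound 3 the estimate in this assay is 90 mg/kg, with a range from 45 mg/kg to 180 mg/kg.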

Compound 3, dose for half-maximal effect: 130 mg/kg
Compound 3: middle estimate off by 1.4-fold (0.16 log units), on the low side; low and high end bracket the measured number.
By their numbers in this assay, from the lowest: compounds 1, 2 and 3 (each within the scatter of the next).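

Among the compounds shown here, the change from phenyl to 3-fluorophenyl gives the first single-change step: a 1.2-fold higher number from compound 2 to compound 3 (0.09 log units; within the scatter) in this assay. On this read-out, compound 2 and compound 3 are equivalent, so the fluoro that compound 3 carries, meta to a large group, shows neither a gain nor a loss. No measured property of either compound is available to bear on this step.

On these data alone, it remains open whether a group other than fluoro at this place, such as methoxy, an amine or a carboxylic acid, would move the number beyond the scatter. Also open is how fluoro would behave on the other carbons of this ring, since the compounds shown cover this one position only.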